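Shortening the piperidine arm of compound 3

A few compounds are considered here, and "the series" means these few. Any claim that something is new, unique, unknown or untested is made for them only; others in the source may bear on it.

Going by the values given here, in a functional assay on HEK293 cells for agonist activity at 5-hydroxytryptamine receptor 4 (Homo sapiens), read by cAMP accumulation (on this read-out higher numbers stand for an effect only at larger amounts of compound and lower numbers for an effect already at smaller amounts), compound 3 `COc1ccc2[nH]cc(C(=O)NCC3CCNCC3)c2c1` gives 6310 nM, the highest number among the three compounds measured so far; compound 1 `COc1cc(N)c(Cl)cc1C(=O)NCC1CCNCC1` gives 398 nM and compound 2 `CC(C)n1c(=O)n(C(=O)NCC2CCNCC2)c2ccccc21` gives 15.9 nM, both beyond the scatter lower than compound 3. All three carry the same (piperidin-4-yl)methyl arm on the amide nitrogen and differ only in their aromatic part, so nothing measured here shows what changing the arm itself does.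

Compound 4 `COc1ccc2[nH]cc(C(=O)NC3CCNCC3)c2c1` keeps the core of compound 3 and alters only that arm: piperidin-4-yl in place of (piperidin-4-yl)methyl on an amide-type nitrogen. Among the compounds with values here, no measured pair in this assay carries this change, so the size of the step cannot be read from the numbers at hand. The expected step in this assay is a 1.9-fold higher number from compound 3 to compound 4 (0.28 log units; within the scatter), pointing toward a larger number, though a step within the scatter is not excluded. For compound 4 the estimate in this assay is 12000 nM, with a range from 3000 nM to 50000 nM, and a real chance that only a limit rather than a number is returned.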

Compound 4, half-maximal effective concentration: 100000000 nM
For compound 4 the middle estimate is 8300-fold (3.92 log units) below the measured one; the measured number lies above the stated range.
By their numbers in this assay, from the lowest: compound 2; then compound 1; then compound 3; then compound 4.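

Going by these compounds alone, replacing (piperidin-4-yl)methyl with piperidin-4-yl on the amide-type nitrogen gives a 16000-fold higher number from compound 3 to compound 4 (4.20 log units; beyond the scatter) in this assay and provides the first reading of a change at this position, since compound 1, compound 2 and compound 3 all carry the same arm. On the core of compound 3, the arm is therefore far from a neutral part of the structure, and the (piperidin-4-yl)methyl form is clearly preferred over piperidin-4-yl. No supporting data explain the size of this step.

Going by these compounds, whether the same shortening has a comparable effect on the cores of compound 1 and compound 2 remains open. Also open, on these data alone, is whether a longer chain, such as (piperidin-4-yl)ethyl, on the core of compound 3 would lower or raise the number further.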